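The source may report more compounds than this note shows. Statements on the series, on what has been measured and on what is new or still open speak of the compounds shown alone.

Measured so far, in an ADME assay for permeability, using PAMPA, with a stated time of 30 min, at pH 7.4; a lower number here means that the compound crosses the layer more slowly, a higher number that the compound crosses the layer faster:
- compound 1, `FC(F)(F)c1ccc(-c2ccc3c(NCCCNCc4ccco4)ccnc3c2)cc1`, gives 237 10^-6 cm/s
- compound 2, `Fc1ccc(Oc2ccc3c(NCCCNCc4ccco4)ccnc3c2)cc1`, gives 317 10^-6 cm/s
- compound 3, `Fc1ccc(Cc2ccc3c(NCCCNCc4ccco4)ccnc3c2)cc1`, gives 23 10^-6 cm/s

Compound 3 stands lowest of the three. From compound 1 to compound 3 the change was a 10-fold lower number from compound 1 to compound 3 (1.01 log units; beyond the scatter), and from compound 2 to compound 3 it was a 14-fold lower number from compound 2 to compound 3 (1.14 log units; beyond the scatter), both large. By contrast, from compound 1 to compound 2 the change was only a 1.3-fold higher number from compound 1 to compound 2 (0.13 log units; within the scatter).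

Compound 4, `COc1ccccc1Oc1ccc2c(NCCCNCc3ccco3)ccnc2c1`, differs from compound 3 in one place: 2-methoxyphenoxy in place of 4-fluorobenzyl on an aromatic carbon. Going by the values given here, the step that bears most directly on this change is the one from compound 2 to compound 3, since compound 2 carries 4-fluorophenoxy on that aromatic carbon and the entering group is likewise a phenoxy. The expectation is therefore a large step up in this assay for compound 4, roughly reversing the drop seen from compound 2 to compound 3, though the extra methoxy leaves some uncertainty. For compound 4 the estimated value is 200 10^-6 cm/s, with a range of 60 10^-6 cm/s to 500 10^-6 cm/s, which is an expected step of an 8.7-fold higher number from compound 3 to compound 4 (0.94 log units; beyond the scatter).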

Compound 4, apparent permeability: 317 10^-6 cm/s
Compound 4: the middle estimate sits 1.6-fold (0.20 log units) below what was measured, and the stated range covers the measured number.
By their numbers in this assay, from the lowest: compound 3; then compounds 1, 2 and 4 (each within the scatter of the next).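

In this assay, the low number of compound 3 does not return with a second phenoxy group on this aromatic carbon: 2-methoxyphenoxy brings a 14-fold higher number from compound 3 to compound 4 (1.14 log units; beyond the scatter). On the oxygen, 2-methoxyphenyl in place of 4-fluorophenyl gives no change at the digits printed from compound 2 to compound 4 (within the scatter), and the directly attached 4-(trifluoromethyl)phenyl group gives a 1.3-fold higher number from compound 1 to compound 4 (0.13 log units; within the scatter), so among these four compounds only compound 3, with 4-fluorobenzyl, stands apart. Nothing shown here explains why 4-fluorobenzyl differs from the other three groups.

From the compounds shown here alone, it remains open whether the low number belongs to the carbon link of the benzyl group or to something else in that group, which a sulfur or carbonyl link in the same place could test. An amine or a carboxylic acid on the outer ring could also show how far this tolerance extends.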